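Lengthening the side chain of compound 3

A few compounds are considered here, and "the series" means these few. Any claim that something is new, unique, unknown or untested is made for them only; others in the source may bear on it.

Measured in a functional assay on the whole organism for positive allosteric modulation, with Mus musculus as the target; on this read-out higher numbers stand for an effect only at larger amounts of compound and lower numbers for an effect already at smaller amounts:
- compound 1 `CCNC1CCCC1N(C(=O)CC)c1ccc(Cl)c(Cl)c1`: 0.2 mg/kg
- compound 2 `C=CCNC1CCCC1N(C(=O)CC)c1ccc(Cl)c(Cl)c1`: 0.2 mg/kg
- compound 3 `CCC(=O)N(c1ccc(Cl)c(Cl)c1)C1CCCC1N(C)CCN(C)C`: 0.8 mg/kg

Compound 3 has the highest number of the three, beyond the scatter of both others. Compound 4 `CCC(=O)N(c1ccc(Cl)c(Cl)c1)C1CCCC1N(C)CCCN(C)C` differs from it by (dimethylamino)methyl in place of dimethylamino on a saturated chain carbon, two bonds along the chain from an amine nitrogen, which also reads 2-(dimethylamino)ethyl to 3-(dimethylamino)propyl. Among the compounds with values here, no measured step makes this change. The nearest, a 4.0-fold higher number from compound 1 to compound 3 (0.60 log units; beyond the scatter) and a 4.0-fold higher number from compound 2 to compound 3 (0.60 log units; beyond the scatter), are modest and exchange the whole amine group. A smaller edit on an amine substituent gave no change at the digits printed from compound 1 to compound 2 (within the scatter). No step beyond the scatter is therefore expected in this assay, and the estimated step is no change at the digits printed from compound 3 to compound 4 (within the scatter). The expected value for compound 4 is 0.8 mg/kg, with an estimated range of 0.3 mg/kg to 2.2 mg/kg.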

Compound 4, dose for half-maximal effect: 4 mg/kg
The estimate for compound 4 lay 5.0-fold (0.70 log units) below the measured number; the measured number lies above the stated range.
By their numbers in this assay, from the lowest: compounds 1 and 2 (each within the scatter of the next); then compound 3; then compound 4.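

In this assay, the side chain is not indifferent to length: 2-(dimethylamino)ethyl to 3-(dimethylamino)propyl gives a 5.0-fold higher number from compound 3 to compound 4 (0.70 log units; beyond the scatter), so this small edit matters more than the earlier allyl-for-ethyl edit on the amine. Within the data shown here, measured against the simple secondary amines, the longer group gives a 20-fold higher number from compound 1 to compound 4 (1.30 log units; beyond the scatter) and a 20-fold higher number from compound 2 to compound 4 (1.30 log units; beyond the scatter), the largest steps so far. Nothing at hand gives a reason for this loss. From the compounds shown here alone, whether a longer chain such as 4-(dimethylamino)butyl continues the rise remains open. So does the effect of a primary amine in place of dimethylamino at the chain end.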